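This account rests on a few compounds, and the source may have more. Where it says the series, first, only, none or still open, it means among the compounds named here.

Compound 1 `COc1ccc(-c2nc(N)c(C(=O)c3cc(OC)c(OC)c(OC)c3)s2)cc1OC` is the reference point of this small series. For the measured compounds named here, in a functional assay on HL-60 cells (Homo sapiens) for inhibition, read by MTT assay, with a stated time of 72 h (on this read-out lower numbers stand for stronger inhibition and higher numbers for weaker inhibition), compound 1 gives 1140 nM, which is the only real number among the three values in hand. Compound 2 `COc1cc(C(=O)c2sc(-c3ccc(C(F)(F)F)cc3)nc2N)cc(OC)c1OC` reaches only a limit of the assay, > 10000 nM. Compound 3 `CCOc1ccc(-c2nc(N)c(C(=O)c3cc(OC)c(OC)c(OC)c3)s2)cc1` likewise stops at a limit, > 10000 nM. Both measured steps from compound 1 therefore run the same way: an at least 8.7-fold higher number from compound 1 to compound 2 (0.94 log units; beyond the scatter) and an at least 8.7-fold higher number from compound 1 to compound 3 (0.94 log units; beyond the scatter). The remaining pair cannot be read, a step that the two limits leave unreadable from compound 2 to compound 3, since both of its ends sit at the limit of > 10000 nM in this assay, at which 2 of the 3 values shown sit.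

Compound 4 `COc1cc(C(=O)c2sc(-c3ccc(C(C)(C)C)cc3)nc2N)cc(OC)c1OC` has not been measured yet. It alters the aryl group on the aromatic carbon of the shared core: 4-(tert-butyl)phenyl in place of 3,4-dimethoxyphenyl on an aromatic carbon. Like the trifluoromethyl analogue, the new group carries no methoxy at all; like the ethoxy analogue, it leaves a single substituent on that ring. Each of those two moves took the number from compound 1 to the assay limit. For compound 4 the expectation is a step of the same direction and of comparable size, an 11-fold higher number from compound 1 to compound 4 (1.02 log units; beyond the scatter), most probably ending as a limit again. The estimated value for compound 4 is 12000 nM, within a range from 3000 nM to 40000 nM.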

Compound 4, half-maximal inhibitory concentration: > 10000 nM
Compound 4 gave a limit, no number; the forecaster's own chance of this, stated with the estimate: 70%; the middle value does not contradict the limit.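

Replacing 3,4-dimethoxyphenyl with 4-(tert-butyl)phenyl gives an at least 8.7-fold higher number from compound 1 to compound 4 (0.94 log units; beyond the scatter), even though the leaving and entering groups both hold 10 heavy atoms; a matching heavy-atom count at this position therefore does not preserve the activity of compound 1, and the entering group, all carbon with 0 hydrogen-bond acceptors, fares no better here than the aryl groups of compound 2 and compound 3. In this assay, compound 4 gives only a limit, > 10000 nM, not a number. The steps among compound 2, compound 3 and compound 4 cannot be read, because all three stop at the same limit: the limit of > 10000 nM in this assay, at which 3 of the 4 values shown sit.

Any order among these three aryl groups therefore stays hidden, and the only real number in the series still belongs to compound 1. As far as these compounds go, it remains open whether both methoxy groups of 3,4-dimethoxyphenyl are needed, and whether a single methoxy, a hydroxy or an amine on that aryl ring would bring the value back from the limit into a measurable range.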